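This account rests on a few compounds, and the source may have more. Where it says the series, first, only, none or still open, it means among the compounds named here.

Measured so far in a physicochemical assay for solubility, read by HPLC, using the shake flask method, in phosphate buffer, measured as kinetic solubility, with a stated time of 20 h, at pH 6.5; a lower number here means a less soluble compound, a higher number a more soluble compound:
- Compound 1 `C[C@@H]1CN(C(=O)c2ccnc(Nc3nc4cnc(Nc5ccc(F)c(C(F)(F)F)c5)cc4[nH]3)c2)C[C@H](C)O1`: < 5000 nM (a limit)
- Compound 2 `C[C@@H]1CN(C(=O)c2ccnc(Nc3nc4cnc(Nc5ccc(F)c(F)c5)cc4[nH]3)c2)C[C@H](C)N1`: 100000 nM

Within the data shown here, compound 2 at 100000 nM holds the only true number so far. Compound 1 at < 5000 nM gives a limit and no number. Compound 3 `C[C@@H]1CN(C(=O)c2ccnc(Nc3nc4cnc(Nc5ccc(F)c(F)c5)cc4[nH]3)c2)C[C@H](C)O1` comes from compound 2 through 2,6-dimethylmorpholin-4-yl in place of 3,5-dimethylpiperazin-1-yl on a carbonyl carbon on a carbonyl carbon. Among the measured compounds shown here, no step between measured compounds exists. For the measured compounds named here, compound 1 also carries 2,6-dimethylmorpholin-4-yl and its limit of < 5000 nM is the only guide. The step expected a 25-fold lower number from compound 2 to compound 3 (1.40 log units; beyond the scatter) is a fall well beyond the scatter in this assay as now estimated. For compound 3 the estimate is 4000 nM with an expected range of 1000 nM to 15000 nM for this measurement.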

Compound 3, solubility: < 5000 nM
Compound 3 ended at the assay's limit; the forecaster's own chance of this, stated with the estimate: 55%; the middle value is on the limit's open side.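

In this assay, among these compounds, 2,6-dimethylmorpholin-4-yl in place of 3,5-dimethylpiperazin-1-yl on a carbonyl carbon gives the first readable step: an at least 20-fold lower number from compound 2 to compound 3 (1.30 log units; beyond the scatter). Compound 3 gives < 5000 nM, a limit and not a number. The step between compound 1 and compound 3, fluoro in place of trifluoromethyl, cannot be read, as both values are limits: the limit of < 5000 nM in this assay, at which 2 of the 3 values shown sit.

Open, from the compounds shown here alone, is where the read-out in this assay would fall with a different group on that carbonyl carbon, such as an open-chain amine or a carboxylic acid. Also open, going by these compounds, is whether 3,5-dimethylpiperazin-1-yl gives a similar value alongside the trifluoromethyl of compound 1.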